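The compounds below may be only part of what the source reports. "The series", "measured", "known", "first", "only" and "open" are said of these compounds alone.

Compound 3 `CCCNNC(=O)c1ccc(CNC(=O)c2cc3cc(F)ccc3[nH]2)cc1` is measured in an assay on isolated protein for inhibition of protein deacetylase HDAC6 (Homo sapiens), read by fluorescence, with a stated time of 2 h (a higher number here means a weaker inhibitor, a lower number a stronger inhibitor), only as a limit of the assay, > 10000 nM. Its two relatives likewise stop at limits. Compound 1 `CCCNNC(=O)c1ccc(CNC(=O)c2ccc3cnccc3c2)cc1` gives in this assay the limit > 10000 nM. Compound 2 `CCCNNC(=O)c1ccc(CNC(=O)c2cc3ccccc3[nH]2)cc1` gives in this assay the limit > 10000 nM. Among the compounds with values here, the single step among them, a step that the two limits leave unreadable from compound 2 to compound 3, brings fluoro in place of hydrogen on an aromatic carbon, yet its size cannot be read; the limit of > 10000 nM in this assay, at which 3 of the 3 values shown sit, records that all three values shown sit at the same limit.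

Compound 4 `CCCNNC(=O)c1ccc(CNC(=O)c2cc3cc(Cl)ccc3[nH]2)cc1` differs from compound 3 by chloro in place of fluoro on an aromatic carbon of a six-membered aromatic ring of carbon only, part of a fused or bridged system of two rings. Within the data shown here, no measured step bears directly on this exchange, and the one step that touches the same position left both of its compounds at the limit, so neither size nor direction can be drawn from it. Because the limit of > 10000 nM in this assay, at which 3 of the 3 values shown sit, shows every value at the same limit, the expectation for compound 4 is another limit rather than a readable number. Compound 4 is therefore estimated at 15000 nM, within a range from 3000 nM to 100000 nM. The step this estimate implies, a step that the limit leaves unreadable from compound 3 to compound 4, is expected to be none beyond the scatter.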

Compound 4, half-maximal inhibitory concentration: > 10000 nM
Compound 4: a limit, no number; the forecaster's own chance of this, stated with the estimate: 85%; the middle value does not contradict the limit.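

In this assay compound 4 gives > 10000 nM, which is a limit of the assay. The steps from compound 2 and from compound 3 to compound 4 therefore cannot be read. The compounds shown leave open how strongly any of them acts, and whether fluoro or chloro in place of hydrogen changes that at all: the limit of > 10000 nM in this assay, at which 4 of the 4 values shown sit.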